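A few compounds are considered here, and "the series" means these few. Any claim that something is new, unique, unknown or untested is made for them only; others in the source may bear on it.

Measured compounds:
- compound 1, `CC1CCN(c2c(S(=O)(=O)c3ccc(C#N)cc3)cnc3cc(Cl)ccc23)CC1`, 70% in an assay on isolated protein for displacement of a labelled ligand from metabotropic glutamate receptor 5 (Homo sapiens), with a stated time of 60 min, tested at 1 uM; on this read-out lower numbers stand for less inhibition and higher numbers for more inhibition at the one concentration tested (going by the name of the read-out)
- compound 2, `CC1CCN(c2c(S(=O)(=O)c3ccc(C#N)cc3)cnc3cc(F)ccc23)CC1`, 83% in this assay
- compound 3, `Cc1cc(C)cc(S(=O)(=O)c2cnc3ccc(F)cc3c2N2CCC(C)CC2)c1`, 83% in this assay

Compound 1 stands lowest of the three in this assay. Going by the values given here, its nearest neighbour on the numbers is compound 2, and the single step between them is a number 13 percentage points higher from compound 1 to compound 2 (beyond the scatter). Among the compounds with values here, compound 3 gives the same value as compound 2, and no single-point step links compound 3 to either of the others, so its number can only be read on its own.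

The unmeasured compound 4, `Cc1ccc(S(=O)(=O)c2cnc3cc(Cl)ccc3c2N2CCC(C)CC2)cc1Cl`, differs from compound 1 in one place: 3-chloro-4-methylphenyl in place of 4-cyanophenyl on a sulfonyl sulfur. No measured step changes the group on the sulfonyl sulfur while leaving everything else fixed, so the only step shown, a number 13 percentage points higher from compound 1 to compound 2 (beyond the scatter), concerns a different position and bears on this change only indirectly. Compound 3, which carries a dimethylphenyl group on the sulfonyl sulfur rather than a cyanophenyl group, matches compound 2 in this assay, which suggests that the sulfonyl aryl group may move the read-out little, though the two also differ elsewhere. Compound 4 is therefore expected to sit close to compound 1, with a change of a number 2 percentage points higher from compound 1 to compound 4 (within the scatter) that lies within the scatter. The estimate for compound 4 in this assay is 72%, ranging from 55% to 88%.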

Compound 4, a percentage reported as inhibition, at one concentration (the size of the read-out at that concentration, not a potency): 89%
Estimate against measurement, compound 4: 17 percentage points below; the whole stated range lies below it.
By their numbers in this assay, from the lowest: compound 1; then compounds 2, 3 and 4 (each within the scatter of the next).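

In this assay, going by these compounds alone, putting 3-chloro-4-methylphenyl in place of 4-cyanophenyl on a sulfonyl sulfur gives a number 19 percentage points higher from compound 1 to compound 4 (beyond the scatter), the first step at this position with everything else in the molecule held fixed, and it shows that the aryl group here does move the read-out. The change takes away the triple bond and the hydrogen-bond acceptor counted in the leaving group, and the read-out does not fall, so neither feature is needed for the inhibition seen at this one concentration. No measurement given here explains why the new group gives the higher number.

The compounds shown do not tell whether the chlorine or the methyl carries this step, since the two enter together, nor whether the same step would hold with fluoro in place of chloro on the aromatic carbon of the shared core. Going by these compounds, it also stays open how an unsubstituted phenyl, or a ring bearing an amine or a carboxylic acid, would read on the sulfonyl sulfur.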